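Aromatic substitution on the shared core: cytotoxicity notes

The source may report more compounds than this note shows. Statements on the series, on what has been measured and on what is new or still open speak of the compounds shown alone.

Compound 1 `COC(=O)N[C@H](C(=O)NN(CCC[C@@](O)(Cc1ccccc1)C(=O)N[C@H]1c2ccccc2C[C@H]1O)Cc1ccccc1)C(C)(C)C` is the parent of the set. In an ADME assay on MT4 cells (Homo sapiens) for cytotoxicity (on this read-out lower numbers stand for higher toxicity in this test and higher numbers for lower toxicity in this test), compound 1 reaches only the limit of the assay, > 10000 nM. Compound 2 `COC(=O)N[C@H](C(=O)NN(CCC[C@@](O)(Cc1ccccc1)C(=O)N[C@H]1c2ccccc2C[C@H]1O)Cc1ccc(-c2nccs2)cc1)C(C)(C)C` carries 1,3-thiazol-2-yl in place of hydrogen on an aromatic carbon; in this assay compound 2 likewise stops at the limit, > 10000 nM. Compound 3 `COC(=O)N[C@H](C(=O)NN(CCC[C@@](O)(Cc1ccccc1)C(=O)N[C@H]1c2ccccc2C[C@H]1O)Cc1ccc(-c2nc(C(C)(C)C)cs2)cc1)C(C)(C)C` carries 4-(tert-butyl)-1,3-thiazol-2-yl in place of hydrogen on an aromatic carbon; in this assay compound 3 also sits at the limit, > 10000 nM. The steps a step that the two limits leave unreadable from compound 1 to compound 2, a step that the two limits leave unreadable from compound 1 to compound 3 and a step that the two limits leave unreadable from compound 2 to compound 3 cannot be sized because of the limit of > 10000 nM in this assay, at which 3 of the 3 values shown sit.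

Compound 4 `COC(=O)N[C@H](C(=O)NN(CCC[C@@](O)(Cc1ccccc1)C(=O)N[C@H]1c2ccccc2C[C@H]1O)Cc1ccc(-c2cccnc2)cc1)C(C)(C)C` is not yet measured. It differs from compound 1 by pyridin-3-yl in place of hydrogen on an aromatic carbon. Going by the values given here, the only bearing evidence is the limit of > 10000 nM in this assay, at which 3 of the 3 values shown sit, and all three measured steps are unreadable. For compound 4 the expected step is therefore a number no higher from compound 1 to compound 4 (the limit leaves the size open), none beyond the scatter, with a limit again the most likely outcome. Compound 4 is expected at 10000 nM, within 5000 nM to 20000 nM, in this assay.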

Compound 4, half-maximal cytotoxic concentration: > 10000 nM
Compound 4 was reported as a limit (the forecaster's own chance of this, stated with the estimate: 85%); the middle value sits exactly at the limit.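

Compound 4 also stops at a limit in this assay, so none of its steps from compound 1, compound 2 or compound 3 can be read: the limit of > 10000 nM in this assay, at which 4 of the 4 values shown sit.

The compounds shown leave open the actual cytotoxic concentration of all four compounds, and whether these aromatic substituents differ at all.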